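The compounds below may be only part of what the source reports. "The series", "measured", "known", "first", "only" and "open" are said of these compounds alone.

Measured compounds:
- compound 1, `O=c1cc(-n2cc(CSc3ccccc3)nn2)c2cc(Br)ccc2o1`: 15400 nM
- compound 2, `O=c1cc(-n2cc(COc3ccccc3)nn2)c2cc(Br)ccc2o1`: 4990 nM
- compound 3, `COC(=O)c1ccccc1OCc1cn(-c2cc(=O)oc3ccc(Br)cc23)nn1`: 20200 nM

In a functional assay on SW480 cells (Homo sapiens) for antiproliferative activity, read by MTT assay, with a stated time of 48 h (a lower number here means a stronger inhibitor, a higher number a weaker inhibitor), compound 1 stands second highest of the three, close to compound 3 and well apart from compound 2. Compound 4, `O=c1cc(-n2cc(COc3ccccc3O)nn2)c2cc(Br)ccc2o1`, differs from compound 1 by 2-hydroxyphenoxy in place of phenylsulfanyl on a saturated chain carbon bound to an aromatic carbon. Among the compounds with values here, two measured steps bear on this. The first, a 3.1-fold lower number from compound 1 to compound 2 (0.49 log units; beyond the scatter), covers the same sulfur-to-oxygen exchange and lowered the number. The second, a 4.0-fold higher number from compound 2 to compound 3 (0.61 log units; beyond the scatter), shows that adding a group to that outer ring can raise it again. Compound 4 combines both kinds of change, so compound 4 is expected to land near compound 2 or somewhat higher, a step of a 2.4-fold lower number from compound 1 to compound 4 (0.37 log units; beyond the scatter). The estimate for compound 4 is 6500 nM, within 2500 nM to 17000 nM.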

Compound 4, half-maximal inhibitory concentration: 19100 nM
The estimate for compound 4 lay 2.9-fold (0.47 log units) below the measured number; the measured number lies above the stated range.
By their numbers in this assay, from the lowest: compound 2; then compounds 1, 4 and 3 (each within the scatter of the next).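

In this assay hydroxy in place of hydrogen on an aromatic carbon raises the number (a 3.8-fold higher number from compound 2 to compound 4 (0.58 log units; beyond the scatter)), so methoxycarbonyl is no longer the only group shown to do so. Hydroxy and methoxycarbonyl at this place cannot be told apart (a 1.1-fold lower number from compound 3 to compound 4 (0.02 log units; within the scatter)), and with hydroxy present the advantage of phenoxy over phenylsulfanyl disappears (a 1.2-fold higher number from compound 1 to compound 4 (0.09 log units; within the scatter)). No measurement shown explains this result.

Going by these compounds, whether an amine or a methoxy group on that aromatic carbon would also raise the number remains open. So does whether any group there can keep the number of compound 2.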